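The source may hold more compounds than are shown below. What is called first, only, known or untested is meant among the compounds shown, and "the series" means these compounds.

The three measured compounds share one core and differ only in the group on the amide-type nitrogen. Compound 1 `COc1ccc(-n2nc(C(=O)Nc3ccccc3OC)nc2-c2cc(OC)c(OC)c(OC)c2)cc1` carries a 2-methoxyphenyl there, and in a functional assay on the whole organism for inhibition, with Rattus norvegicus as the target, read by paw edema, with stated times of 30 min and 2 h, at a dose of 0.28 mmol/kg by the oral route (a higher number here means more inhibition at the dose given (going by the name of the read-out), a lower number less inhibition), compound 1 gives 57%. Compound 3 `COc1ccc(-n2nc(C(=O)Nc3ccc(C(F)(F)F)cc3)nc2-c2cc(OC)c(OC)c(OC)c2)cc1` carries a 4-(trifluoromethyl)phenyl, and compound 3 gives 55%. Compound 2 `COc1ccc(-n2nc(C(=O)Nc3ccccc3C)nc2-c2cc(OC)c(OC)c(OC)c2)cc1` carries a 2-methylphenyl, and compound 2 gives 30%, the lowest of the three numbers; its gap to compound 3 is a number 25 percentage points higher from compound 2 to compound 3 (beyond the scatter), and the step of a number 27 percentage points lower from compound 1 to compound 2 (beyond the scatter) is of similar size, while a number 2 percentage points lower from compound 1 to compound 3 (within the scatter) lies within the scatter.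

Compound 4 `COc1ccc(-n2nc(C(=O)Nc3ccccc3)nc2-c2cc(OC)c(OC)c(OC)c2)cc1` is the next step from compound 2: hydrogen in place of methyl on an aromatic carbon. For the measured compounds named here, no measured step removes a methyl outright, so the bearing steps are only indirect; both changes away from the 2-methylphenyl of compound 2 gave modest rises. An upward step is therefore expected, estimated as a number 15 percentage points higher from compound 2 to compound 4 (beyond the scatter), though with wide uncertainty. Compound 4 is estimated at 45%, within a range from 25% to 65%.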

Compound 4, a percentage reported as inhibition, in the whole organism at one dose (the size of the read-out at that dose, not a potency): 51%
Beside the measured number, compound 4's estimate is 6 percentage points below it, within the range that was stated.
By their numbers in this assay, from the lowest: compound 2; then compounds 4, 3 and 1 (each within the scatter of the next).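

Compound 4 supplies the unsubstituted phenyl reference, and against it the methyl, ortho to a large group, proves to be a detriment in its own right: a number 21 percentage points higher from compound 2 to compound 4 (beyond the scatter) in this assay is beyond the scatter. The steps of a number 4 percentage points lower from compound 3 to compound 4 (within the scatter) and a number 6 percentage points lower from compound 1 to compound 4 (within the scatter) both lie within the scatter, so among these compounds only the methyl separates from hydrogen, while the methoxy of compound 1 and the trifluoromethyl of compound 3 do not. Nothing measured here bears on the cause of this drop.

Going by these compounds, whether the drop is particular to methyl, or also appears with ethyl or an amine on the same ring carbon, remains open. Whether methyl lowers the read-out elsewhere on the ring also remains open, as the only methyl shown is the one in compound 2.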